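The compounds below may be only part of what the source reports. "The series", "measured", "known", "first", "only" and "open" are said of these compounds alone.

Three compounds share one core and differ only in the group on the ring nitrogen. Compound 3 `CC(C)SC(=O)N1CCC(Oc2ncnc3c2CCN3c2ccc(S(C)(=O)=O)cc2F)CC1` stands at the lowest number of the three: in a functional assay on CHO-K1 cells for agonist activity at Glucose-dependent insulinotropic receptor (Homo sapiens), read by a luciferase reporter, with a stated time of 5 h (on this read-out lower numbers stand for an effect already at smaller amounts and higher numbers for an effect only at larger amounts of compound), compound 3 gives 10 nM. Compound 2 `CCSC(=O)N1CCC(Oc2ncnc3c2CCN3c2ccc(S(C)(=O)=O)cc2F)CC1` gives 31.6 nM, and compound 1 `COCCOC(=O)N1CCC(Oc2ncnc3c2CCN3c2ccc(S(C)(=O)=O)cc2F)CC1` gives 316 nM. The steps of a 10-fold lower number from compound 1 to compound 2 (1.00 log units; beyond the scatter) and a 32-fold lower number from compound 1 to compound 3 (1.50 log units; beyond the scatter) show that changing this group shifts the number strongly, while a 3.2-fold lower number from compound 2 to compound 3 (0.50 log units; beyond the scatter) is smaller. Compound 4 `CN(C)S(=O)(=O)N1CCC(Oc2ncnc3c2CCN3c2ccc(S(C)(=O)=O)cc2F)CC1` carries yet another group there: dimethylsulfamoyl in place of (isopropylsulfanyl)carbonyl on an amine nitrogen in a ring. Among the measured compounds shown here, no measured step exchanges a carbonyl for a sulfonyl, so the direction is uncertain; compound 1 shows that a group without a sulfur on the carbonyl sits far higher. Compound 4 is therefore expected to give about 100 nM, between 20 nM and 500 nM, an estimated step of a 10-fold higher number from compound 3 to compound 4 (1.00 log units; beyond the scatter).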

Compound 4, half-maximal effective concentration: 398 nM
For compound 4 the middle estimate is 4.0-fold (0.60 log units) below the measured one; measured number inside the range.
By their numbers in this assay, from the lowest: compound 3; then compound 2; then compounds 1 and 4 (each within the scatter of the next).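

The swap to dimethylsulfamoyl gives a 40-fold higher number from compound 3 to compound 4 (1.60 log units; beyond the scatter) and a 13-fold higher number from compound 2 to compound 4 (1.10 log units; beyond the scatter) even though a sulfur stays in the group, so a sulfur alone does not keep the number low at this ring nitrogen. Against (2-methoxyethoxy)carbonyl, the same group gives a 1.3-fold higher number from compound 1 to compound 4 (0.10 log units; within the scatter) and so no real separation from it.

Still open, on these data alone, is whether the carbonyl, the sulfanyl link or both matter, which a methanesulfonyl group or a urea carrying an isopropylamino group could help to separate. Nothing measured here explains the gap between these groups.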